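The compounds below may be only part of what the source reports. "The series", "measured", "known", "first", "only" and "open" are said of these compounds alone.

Going by the values given here, only two compounds have a number so far in an ADME assay on L6 cells (Rattus norvegicus) for cytotoxicity, read by resazurin assay, with a stated time of 72 h; on this read-out higher numbers stand for weaker inhibition and lower numbers for stronger inhibition. There, compound 1 `OC(c1ccc(Cl)cc1)(c1ccc(Br)cc1)c1cccnc1` gives 57000 nM and compound 2 `CC(C)Oc1ccccc1C(O)(c1ccc(Cl)cc1)c1cccnc1` gives 48300 nM. These two values lie within the scatter of each other, so compound 2 stands level with compound 1 on the numbers shown.

Compound 3 `OC(c1ccc(Cl)cc1)(c1cccnc1)c1ccccc1Br` has not yet been measured. It differs from compound 2 by one change, bromo in place of isopropoxy on an aromatic carbon of a six-membered aromatic ring of carbon only, ortho to a large group: bromo in place of isopropoxy on an aromatic carbon. Among the compounds with values here, no measured pair shows this change directly, so the size of the step in this assay cannot be read from the data. None beyond the scatter is expected, in either direction. That expectation rests on compound 1, which also carries a bromo group and gives 57000 nM, close to compound 2 at 48300 nM. The expected change is a 1.0-fold higher number from compound 2 to compound 3 (0.02 log units; within the scatter). For compound 3 the estimated value is 50000 nM, with an expected range from 25000 nM to 95000 nM.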

Compound 3, half-maximal inhibitory concentration: 55200 nM
For compound 3 the middle estimate is 1.1-fold (0.04 log units) below the measured one; the measured number falls inside the stated range.
By their numbers in this assay, from the lowest: compounds 2, 3 and 1 (each within the scatter of the next).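

In this assay, going by these compounds alone, bromo in place of isopropoxy on an aromatic carbon, ortho to a large group, gives a 1.1-fold higher number from compound 2 to compound 3 (0.06 log units; within the scatter) and so provides the first direct reading of this change, which leaves the number level with that of compound 2. The 2-bromophenyl in place of 4-bromophenyl gives a 1.0-fold lower number from compound 1 to compound 3 (0.01 log units; within the scatter), so these compounds also show no separation between the two bromophenyl groups, and across the three compounds neither the larger isopropoxy nor the single bromine atom stands apart on this read-out. No measurement is at hand that could explain why these compounds stand level.

Bromo and isopropoxy are the only groups compared on this aromatic carbon, so it remains open whether an amine, a carboxylic acid or a longer chain there would give a step beyond the scatter. The rest of the shared core stays the same across all three compounds, which leaves the effect of any change elsewhere on it unknown.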